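Nitro in place of hydrogen on a benzoxazolone-type amide

This account rests on a few compounds, and the source may have more. Where it says the series, first, only, none or still open, it means among the compounds named here.

Measured so far:
Compound 1, `O=C(Cn1c(=O)oc2cc([N+](=O)[O-])ccc21)Nc1ccccn1`: 47.3%
Compound 2, `O=C(Cn1c(=O)oc2ccccc21)NCc1cccs1`: 49.1%

Both compounds were tested in an ADME assay on RAW264.7 cells (Mus musculus) for cytotoxicity, read by MTT assay, with a stated time of 72 h, tested at 100 uM; on this read-out higher numbers stand for a stronger effect at the one concentration tested and lower numbers for a weaker effect. Compound 1 gives 47.3% and compound 2 gives 49.1%. Compound 2 has the higher of the two numbers, but the gap to compound 1 is within the usual scatter of repeated measurements, so the two values cannot be told apart. For the measured compounds named here, the two compounds differ in more than one place, so no single step connects them.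

Compound 3, `O=C(Cn1c(=O)oc2cc([N+](=O)[O-])ccc21)NCc1cccs1`, has not yet been measured. It differs from compound 2 in one place: nitro in place of hydrogen on an aromatic carbon. Compound 1 already carries the same nitro group on the same position of the shared core, and its value lies within the scatter of compound 2. Going by the values given here, nothing among the measured compounds therefore points to a step beyond the scatter, in either direction, in this assay .

For compound 3 the expected value is 48%, with a range from 35% to 62%. The expected step is a number 1.1 percentage points lower from compound 2 to compound 3 (within the scatter), essentially none beyond the scatter.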

Compound 3, a percentage reported as inhibition, at one concentration (the size of the read-out at that concentration, not a potency): 41%
Compound 3: middle estimate off by 7 percentage points, on the high side; the range from low to high includes it.
By their numbers in this assay, from the lowest: compounds 3, 1 and 2 (each within the scatter of the next).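

In this assay, nitro in place of hydrogen on an aromatic carbon can now be read as a single change on the shared core, with the (thiophen-2-yl)methyl amide held constant: the change gives a number 8.1 percentage points lower from compound 2 to compound 3 (within the scatter) and so cannot be separated from the ordinary spread of repeated measurements. With the nitro group kept in place, (thiophen-2-yl)methyl in place of pyridin-2-yl on the amide-type nitrogen gives a number 6.3 percentage points lower from compound 1 to compound 3 (within the scatter) and is equally unresolved, so neither single change has a measurable consequence for this cytotoxicity read-out among these compounds. No measurement shown here offers an explanation for these small differences.

From the compounds shown here alone, whether an amine or a carboxylic acid in place of the nitro group on this aromatic carbon would produce a step beyond the scatter stays open, as does the outcome for a longer chain in place of (thiophen-2-yl)methyl on the amide-type nitrogen. Each number is also a reading at a single concentration, so these compounds leave open how their potencies compare.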